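Working notes: from compound 3 to compound 4

The source may hold more compounds than are shown below. What is called first, only, known or untested is meant among the compounds shown, and "the series" means these compounds.

In a functional assay on A2780 cells (Homo sapiens) for antiproliferative activity, read by CellTiter-Glo, with a stated time of 4 days (a higher number here means a weaker inhibitor, a lower number a stronger inhibitor), compound 1 (`CC(=O)NCc1ncc2cc(COc3ccc(C(=O)NCc4cccnc4)cc3)n(CCC3CCCCC3)c2n1`) gives 15 nM as its half-maximal inhibitory concentration. Compound 2 (`O=C(CCc1cccnc1)Nc1ccc(CN2C(=O)c3ccccc3C2=O)cc1`) reads > 10000 nM in this assay, and this is a limit, not a number. Compound 3 (`CCC(=O)N[C@@H](C)c1ccc(NC(=O)[C@H]2C[C@@H]2c2cccnc2)cc1`) at 5 nM holds the lower of the two numbers, a gap to compound 1 that lies beyond the scatter. Compound 4 (`C[C@H](NC(=O)c1ccc(C#N)cc1)c1ccc(NC(=O)[C@H]2C[C@@H]2c2cccnc2)cc1`) carries 4-cyanophenyl in place of ethyl on a carbonyl carbon. For the measured compounds named here, no measured step covers this change, so only a weak expectation is possible: no shift beyond the scatter in this assay. The expected step is a 1.2-fold higher number from compound 3 to compound 4 (0.08 log units; within the scatter) in this assay. For compound 4 the estimate is 6 nM, with 1.5 nM to 25 nM as the expected range.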

Compound 4, half-maximal inhibitory concentration: 4 nM
Estimate against measurement, compound 4: 1.5-fold (0.18 log units) above; the range from low to high includes it.
By their numbers in this assay, from the lowest: compounds 4 and 3 (each within the scatter of the next); then compound 1. At a limit, above all of these: compound 2.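

Replacing ethyl with 4-cyanophenyl on a carbonyl carbon gives a 1.3-fold lower number from compound 3 to compound 4 (0.10 log units; within the scatter) in this assay. This position therefore carries a six-membered aromatic ring with a nitrile as well as a two-carbon ethyl group, with no shift beyond the scatter. Nothing at hand gives a cause for this step. Going by these compounds, whether an unsubstituted phenyl would read the same stays open, so the share of the nitrile cannot be told. An amine or a carboxylic acid on this carbonyl carbon also remains an open case.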